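Quinone chain-end variants: growth inhibition working notes

The source may report more compounds than this note shows. Statements on the series, on what has been measured and on what is new or still open speak of the compounds shown alone.

Measured so far:
compound 1 `COC1=C(OC)[C@H](O)[C@H](C/C=C(\C)CC/C=C(\C)C[C@@H]2C[C@@H](C)C(=O)O2)[C@@H](C)C1=O` — in a functional assay on PC-3 cells (Homo sapiens) for inhibition, read by sulforhodamine B assay, with a stated time of 48 h (on this read-out higher numbers stand for weaker inhibition of growth and lower numbers for stronger inhibition of growth), compound 1 gives > 30000 nM, which is a limit of the assay.
compound 2 `COC1=C(OC)[C@H](O)[C@H](C/C=C(\C)CC/C=C(\C)C[C@H](O)/C=C(\C)CO)[C@@H](C)C1=O` — in this assay compound 2 gives > 30000 nM, again a limit.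
compound 3 `COC1=C(OC)[C@H](OC(C)=O)[C@H](C/C=C(\C)CC/C=C(\C)C[C@H](O)/C=C(\C)CO)[C@@H](C)C1=O` — in this assay compound 3 gives > 30000 nM, again a limit.

Among the compounds with values here, all three values sit at the limit of > 30000 nM in this assay, at which 3 of the 3 values shown sit, so none of the measured steps can be sized. From compound 2 to compound 1 the change is a group of 7 heavy atoms (5 carbon, 2 oxygen; one five-membered non-aromatic ring with 1 hetero atom) in place of a group of 7 heavy atoms (5 carbon, 2 oxygen; no ring), on a saturated chain carbon bound to a double-bonded chain carbon; the step is a step that the two limits leave unreadable from compound 2 to compound 1. The cores of compound 2 and compound 3 differ by acetyl in place of hydrogen on an oxygen on a saturated carbon; the step is a step that the two limits leave unreadable from compound 2 to compound 3.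

Compound 4 `COC1=C(OC)[C@H](OC(C)=O)[C@H](C/C=C(\C)CC/C=C(\C)C[C@@H]2C[C@@H](C)C(=O)O2)[C@@H](C)C1=O` has not yet been measured. It differs from compound 3 by a group of 7 heavy atoms (5 carbon, 2 oxygen; one five-membered non-aromatic ring with 1 hetero atom) in place of a group of 7 heavy atoms (5 carbon, 2 oxygen; no ring), on a saturated chain carbon bound to a double-bonded chain carbon. This is the same change as from compound 2 to compound 1, and the place is described in the same words, so it is the same change made on the other core.

Within the data shown here, the expected step from compound 3 to compound 4 is a step that the limit leaves unreadable from compound 3 to compound 4, placed beside the earlier step, which has no readable size; the expectation rests on (the limit of > 30000 nM in this assay, at which 3 of the 3 values shown sit), where every value so far sits, with no measured change within the set that moves any compound off it.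

For compound 4 the estimate is 40000 nM, expected to lie between 15000 nM and 100000 nM, and most probably reported as a limit again.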

Compound 4, concentration for 50% growth inhibition: > 30000 nM
Compound 4: no number, only a limit; the forecaster's own chance of this, stated with the estimate: 85%; the middle value does not contradict the limit.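

In this assay compound 4 gives > 30000 nM as a limit. Within the data shown here, the steps to compound 4 from compound 3 and from compound 1 cannot be read, so this result yields no new step: the limit of > 30000 nM in this assay, at which 4 of the 4 values shown sit.

The compounds shown leave open whether any change at the chain end or on the oxygen moves growth inhibition off this limit, and by how much.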